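Triazole to imidazole in an imidazoline-bearing aniline series

The source may report more compounds than this note shows. Statements on the series, on what has been measured and on what is new or still open speak of the compounds shown alone.

Compound 1 `Cn1ncnc1-c1ccccc1NCC1=NCCN1` in an in vitro functional assay on cells (Fibroblast) for agonist activity at Alpha-1D adrenergic receptor (Homo sapiens) (a higher number here means that more compound is needed for the effect, a lower number that less compound is needed), gives 63.1 nM. Compound 2 `CC(C)n1ncnc1-c1ccccc1NCC1=NCCN1` in this assay gives 3160 nM.

Compound 1 stands lowest of the two numbers measured; its nearest neighbour is compound 2, reached by the change a 50-fold higher number from compound 1 to compound 2 (1.70 log units; beyond the scatter), a large step. Compound 3 `Cn1ccnc1-c1ccccc1NCC1=NCCN1` has not yet been measured. It differs from compound 1 by the change (1-methyl-1H-imidazol-2-yl in place of 1-methyl-1H-1,2,4-triazol-5-yl on an aromatic carbon), so the methyl on the aromatic nitrogen stays in place and only the ring that carries it is exchanged.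

Among the measured compounds shown here, none of the measured steps bears on this change. For the measured compounds named here, the one step that exists, from compound 1 to compound 2, concerns the size of the group on the aromatic nitrogen and leaves the triazole untouched, so it gives no guide to what swapping the triazole for an imidazole does. Going by the values given here, with no comparable step among the measured compounds, the expectation for compound 3 is a step of no clear direction, a 1.3-fold higher number from compound 1 to compound 3 (0.10 log units; within the scatter), and the estimate is set near compound 1 with a wide range: compound 3 is expected to give 80 nM in this assay, between 15 nM and 400 nM.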

Compound 3, half-maximal effective concentration: 200 nM
Estimate against measurement, compound 3: 2.5-fold (0.40 log units) below; the range from low to high includes it.
By their numbers in this assay, from the lowest: compound 1; then compound 3; then compound 2.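

In this assay, the ring that carries the methyl group proves to count as well: 1-methyl-1H-imidazol-2-yl in place of 1-methyl-1H-1,2,4-triazol-5-yl gives a modest change (a 3.2-fold higher number from compound 1 to compound 3 (0.50 log units; beyond the scatter)). Among the compounds shown here, until this result, only the group on the aromatic nitrogen had been seen to move the number, and by a large step (a 50-fold higher number from compound 1 to compound 2 (1.70 log units; beyond the scatter)), whereas this exchange leaves that methyl in place and still moves the number beyond the scatter. The two rings have the same count of heavy atoms and differ in one ring nitrogen exchanged for carbon and in their hydrogen-bond acceptors, but no available evidence connects the step to either difference.

The compounds shown leave open whether isopropyl on the imidazole nitrogen would raise the number as it does on the triazole, and whether an intermediate group such as ethyl would give a smaller step on either ring. They also leave open how other rings on this aromatic carbon, such as an oxazole, a pyridine or a plain phenyl, would compare with the triazole of compound 1.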